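Side-chain change from compound 2 to compound 3

This account rests on a few compounds, and the source may have more. Where it says the series, first, only, none or still open, it means among the compounds named here.

Compound 1 `C=C(C)COOC1(OOC)CCCCCCCCCCC1`: 17000 nM
Compound 2 `CCCCOOC1(OOC)CCCCCCCCCCC1`: 20000 nM

In a functional assay on FM3A cells (Mus musculus) for cytotoxicity (on this read-out lower numbers stand for an effect already at smaller amounts and higher numbers for an effect only at larger amounts of compound), these two compounds lie within the scatter of each other, so compound 2 stands level with compound 1. Compound 3 `COOC1(OOCCCc2ccccc2)CCCCCCCCCCC1` differs from compound 2 by phenyl in place of methyl on a saturated chain carbon, three bonds along the chain from an oxygen on an unsaturated carbon. Going by the values given here, the only measured step, a 1.2-fold higher number from compound 1 to compound 2 (0.07 log units; within the scatter), involves a different change and offers weak guidance. No shift beyond the scatter is expected, and the expected step is a 1.2-fold lower number from compound 2 to compound 3 (0.07 log units; within the scatter). For compound 3 the estimated value is 17000 nM, with an expected range of 6000 nM to 45000 nM.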

Compound 3, half-maximal effective concentration: 34000 nM
Beside the measured number, compound 3's estimate is 2.0-fold (0.30 log units) below it; measured number inside the range.
By their numbers in this assay, from the lowest: compounds 1, 2 and 3 (each within the scatter of the next).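

In this assay, phenyl in place of methyl, on a saturated chain carbon, three bonds along the chain from an oxygen on an unsaturated carbon, gives a 1.7-fold higher number from compound 2 to compound 3 (0.23 log units; within the scatter). Phenethyl in place of 1-methylethenyl gives a 2.0-fold higher number from compound 1 to compound 3 (0.30 log units; within the scatter), so among these compounds a six-membered aromatic ring at the end of this side chain brings no shift beyond the scatter. Nothing available bears on a cause.

Going by these compounds, whether an amine, a carboxylic acid or a longer chain ending in phenyl at this place would move the number beyond the scatter stays open.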